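The source may report more compounds than this note shows. Statements on the series, on what has been measured and on what is new or still open speak of the compounds shown alone.

Compound 1 `Cc1cc(Cl)ccc1CC(C)C(=O)N1CCN(c2ccc(C(F)(F)F)cc2[C@@H](N)CC(C)C)CC1` carries a branched arylalkyl group on the amide carbonyl of the shared core. For the measured compounds named here, in an assay on HEK293 cells for displacement of a labelled ligand from Melanocortin receptor 4 (Homo sapiens) (a higher number here means a weaker inhibitor, a lower number a stronger inhibitor), compound 1 gives 38 nM, the lowest of the three numbers measured so far. Compound 2 `CC(C)C[C@H](N)c1cc(C(F)(F)F)ccc1N1CCN(C(=O)CCC2CCCCC2)CC1`, which instead bears 2-cyclohexylethyl on that carbonyl carbon, gives 5700 nM in this assay, and compound 3 `COc1cc(CC(C)C(=O)N2CCN(c3ccc(C(F)(F)F)cc3[C@@H](N)CC(C)C)CC2)ccc1Cl`, with 4-chloro-3-methoxyphenyl in place of 4-chloro-2-methylphenyl on the chain, gives 230 nM.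

Compound 4 `CC(C)C[C@H](N)c1cc(C(F)(F)F)ccc1N1CCN(C(=O)COc2ccc([N+](=O)[O-])cc2)CC1` differs from compound 1 at the same carbonyl carbon: (4-nitrophenoxy)methyl in place of 1-(4-chloro-2-methylbenzyl)ethyl on a carbonyl carbon. Going by the values given here, two measured steps bear on this. Replacing the whole arylalkyl group with a saturated one gave a 150-fold higher number from compound 1 to compound 2 (2.18 log units; beyond the scatter), a large loss. Keeping an aromatic ring but changing its substituents gave a 6.1-fold higher number from compound 1 to compound 3 (0.78 log units; beyond the scatter), a modest loss. Compound 4 keeps an aromatic ring yet changes the substituents, the linker and the branching at once, so a loss larger than that of compound 3 but smaller than that of compound 2 seems likely.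

Compound 4 is therefore expected to give 1200 nM in this assay, within 200 nM to 7000 nM, a step of a 32-fold higher number from compound 1 to compound 4 (1.50 log units; beyond the scatter).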

Compound 4, inhibition constant: 3100 nM
Estimate against measurement, compound 4: 2.6-fold (0.41 log units) below; measured number inside the range.
By their numbers in this assay, from the lowest: compound 1; then compound 3; then compounds 4 and 2 (each within the scatter of the next).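

In this assay, an aromatic ring on this chain is not enough to keep the number low: (4-nitrophenoxy)methyl also carries one six-membered aromatic ring, yet it loses heavily against both arylalkyl groups (an 82-fold higher number from compound 1 to compound 4 (1.91 log units; beyond the scatter); a 13-fold higher number from compound 3 to compound 4 (1.13 log units; beyond the scatter)). Compared with the saturated chain of compound 2, it offers no measurable gain, as this step lies within the scatter (a 1.8-fold lower number from compound 2 to compound 4 (0.26 log units; within the scatter)). No measurement shown here gives a reason for these steps.

Because the ring substituents, the chain and its branching all change together, the step cannot be assigned to any one of them. A (4-chlorophenoxy)methyl group on the same carbonyl carbon would show how much depends on the nitro group, and how much on the rest of the change.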